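The source may report more compounds than this note shows. Statements on the series, on what has been measured and on what is new or still open speak of the compounds shown alone.

Measured in a physicochemical assay for solubility; on this read-out lower numbers stand for lower solubility and higher numbers for higher solubility:
- compound 1 `CNC(=O)c1cc(C(=O)N[C@H]2[C@@H]3C[C@@H](OC)C[C@@H]32)n([C@@H](C)c2ccccc2)n1`: >= 150 ug/mL (a limit of the assay)
- compound 2 `CCCNC(=O)c1cc(C(=O)NC)nn1[C@@H](C)c1ccccc1`: >= 132 ug/mL (a limit of the assay)
- compound 3 `CNC(=O)c1cc(C(=O)NC2CCOCC2)n([C@@H](C)c2ccccc2)n1`: 31 ug/mL

For the measured compounds named here, compound 3 at 31 ug/mL gives the only true number in this set, and it stands lowest of the three. The other two values are limits, so the steps to compound 3 have a known minimum size but no exact size.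

Compound 4 `CNC(=O)c1cc(C(=O)NCCO)n([C@@H](C)c2ccccc2)n1` is not yet measured. It differs from compound 3 as follows: 2-hydroxyethyl in place of oxan-4-yl on an amide-type nitrogen. In words, this is 2-hydroxyethyl in place of oxan-4-yl on an amide-type nitrogen.

The closest measured change is an at least 4.2-fold lower number from compound 2 to compound 3 (0.62 log units; beyond the scatter), which puts oxan-4-yl in place of propyl at that same kind of nitrogen. The step of an at least 4.8-fold lower number from compound 1 to compound 3 (0.68 log units; beyond the scatter) points the same way, while a step that the two limits leave unreadable from compound 1 to compound 2 gives no usable size. Both readable steps end on the oxan-4-yl compound, so removing that group is expected to raise the number by a similar margin. Going by the values given here, no measured compound carries 2-hydroxyethyl, which keeps the expected range wide.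

The expected move is a 4.8-fold higher number from compound 3 to compound 4 (0.68 log units; beyond the scatter), upward and probably beyond the scatter. The estimate for compound 4 is 150 ug/mL, with an expected range of 60 ug/mL to 400 ug/mL.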

Compound 4, solubility: >= 139 ug/mL
Compound 4 ended at the assay's limit; the forecaster's own chance of this, stated with the estimate: 55%; the middle value is on the limit's open side.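

In this assay, 2-hydroxyethyl in place of oxan-4-yl on the amide-type nitrogen gives an at least 4.4-fold higher number from compound 3 to compound 4 (0.65 log units; beyond the scatter), so this position now has a step that leaves oxan-4-yl for a group carrying a hydroxy and no ring, and the number rises beyond the scatter. Compound 4 gives >= 139 ug/mL, which is a limit of the assay, so the step has a minimum size and no exact size: the limit of >= 139 ug/mL in this assay, at which 1 of the 4 values shown sits.

For the compounds shown here, with this result, compound 3 is the only one of the four compounds below the limits, while compound 1, which keeps a ring system on this nitrogen, and compounds 2 and 4, with open chains, all end at limits; the steps among those three cannot be read, and the low number therefore belongs to oxan-4-yl alone and not to ring-bearing groups in general.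

From the compounds shown here alone, how far propyl, 2-hydroxyethyl and the group of compound 1 differ from one another stays open, as all three sit at limits in this assay. Also open, going by these compounds, is whether an open-chain ether such as 2-methoxyethyl, a 2-aminoethyl group or a carboxylic acid on this nitrogen would stay at a limit or fall towards compound 3.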